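A few compounds are considered here, and "the series" means these few. Any claim that something is new, unique, unknown or untested is made for them only; others in the source may bear on it.

Measured so far in a physicochemical assay for solubility, in simulated intestinal fluid, with a stated time of 4 h; a lower number here means a less soluble compound, a higher number a more soluble compound
compound 1 `N#Cc1ccc(O[C@H]2CN(S(=O)(=O)c3ccc(Cl)cc3Cl)C[C@@]2(O)CO)cc1F` gives 19 ug/mL
compound 2 `N#Cc1ccc(O[C@H]2CN(S(=O)(=O)c3ccc(Cl)cn3)C[C@@]2(O)CO)cc1F` gives 26 ug/mL
compound 3 `N#Cc1ccc(O[C@H]2CN(S(=O)(=O)c3ccc(C(F)(F)F)nc3)C[C@@]2(O)CO)cc1F` gives 98 ug/mL

Compound 2 cannot be told apart from compound 1 (a 1.4-fold higher number from compound 1 to compound 2 (0.14 log units; within the scatter)) and sits clearly under compound 3 (a 3.8-fold higher number from compound 2 to compound 3 (0.58 log units; beyond the scatter)). Compound 3 also stands clear of compound 1 (a 5.2-fold higher number from compound 1 to compound 3 (0.71 log units; beyond the scatter)).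

Compound 4 `N#Cc1ccc(O[C@H]2CN(S(=O)(=O)c3ccc(Cl)cn3)C[C@]2(O)CO)cc1F` differs from compound 2 in configuration alone (the two compounds have the same atoms and bonds and differ only in configuration as drawn: 1 of 2 stereo elements differ; a stereocentre at a saturated ring carbon is drawn R in compound 2 and S in compound 4). Nothing leaves and nothing enters, so the group on the sulfonyl sulfur and the rest of the shared core stay the same. All three measured steps exchange the group on the sulfonyl sulfur, and none changes configuration. They show how far the number has moved for a different kind of change, from within the scatter to modest, but give no direct reading for this one. Among the measured compounds shown here, the data hold no measured pair of stereoisomers, so the margin stays wide. The best anchor is compound 2 itself (26 ug/mL). No step beyond the scatter is expected in this assay in either direction (estimated no change at the digits printed from compound 2 to compound 4 (within the scatter)). Compound 4 is estimated at 26 ug/mL (expected range 10 ug/mL to 68 ug/mL).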

Compound 4, solubility: 130 ug/mL
The estimate for compound 4 lay 5.0-fold (0.70 log units) below the measured number; the measured number lies above the stated range.
By their numbers in this assay, from the lowest: compounds 1 and 2 (each within the scatter of the next); then compounds 3 and 4 (each within the scatter of the next).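

In this assay, the stereocentre at a saturated ring carbon alone gives a 5.0-fold higher number from compound 2 to compound 4 (0.70 log units; beyond the scatter), and this step can be placed on that stereocentre because of one fact: the fact that compounds 2 and 4 differ only in the configuration as drawn. The earlier steps shown here all exchanged the group on the sulfonyl sulfur, so they could not show that configuration matters; here the 5-chloropyridin-2-yl group stays in place and the number still moves beyond the scatter. The step is graded modest, like a 3.8-fold higher number from compound 2 to compound 3 (0.58 log units; beyond the scatter), so in this one pair a change of configuration reaches the same grade as an exchange of the group on the sulfonyl sulfur.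

The compounds shown leave open whether the S configuration at this carbon gives a similar step with 2,4-dichlorophenyl or 6-(trifluoromethyl)pyridin-3-yl on the sulfonyl sulfur, and what the other stereocentre contributes. They also leave open how the number in this assay would respond to an amine or a carboxylic acid in place of the 5-chloropyridin-2-yl on the sulfonyl sulfur, in either configuration.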